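Working notes: ethoxy to 3-nitrophenoxy step in the series

This account rests on a few compounds, and the source may have more. Where it says the series, first, only, none or still open, it means among the compounds named here.

Measured so far:
compound 1, `COc1ccc([C@@H]2C/C(=N/OCc3cn(-c4ccccc4CO)nn3)c3cc(CC=C(C)C)c(OC)cc3O2)cc1` — 100%
compound 2, `CCOc1ccc([C@@H]2CC(=O)c3cc(CC=C(C)C)c(OC)cc3O2)cc1` — 65%

Both numbers come from a functional assay on HCT-116 cells (Homo sapiens) for inhibition, read by sulforhodamine B assay, with a stated time of 48 h, tested at 50 uM; on this read-out lower numbers stand for less inhibition of growth and higher numbers for more inhibition of growth at the one concentration tested. Compound 2 stands lowest of the two, compound 1 giving a number higher by a margin beyond the usual scatter. For the measured compounds named here, no step of a single change links the pair, so only the two values themselves are known.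

Compound 3, `COc1cc2c(cc1CC=C(C)C)C(=O)C[C@@H](c1ccc(Oc3cccc([N+](=O)[O-])c3)cc1)O2`, is not yet measured. It follows from compound 2 by one change: 3-nitrophenyl in place of ethyl on an oxygen on an aromatic ring. Nothing measured speaks to a 3-nitrophenyl in place of ethyl on an oxygen on an aromatic ring. In this assay no step beyond the scatter is expected from compound 2 to compound 3, with a slight lean upward because compound 2 already gives 65% and leaves room on the read-out. The expected step is a number 5 percentage points higher from compound 2 to compound 3 (within the scatter). Compound 3 is expected to give 70%, in the range 45% to 92%.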

Compound 3, percent growth inhibition at one concentration: 46%
Compound 3: middle estimate off by 24 percentage points, on the high side; low and high end bracket the measured number.
By their numbers in this assay, from the lowest: compound 3; then compound 2; then compound 1.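

In this assay, for the compounds shown here, 3-nitrophenyl in place of ethyl on an oxygen on an aromatic ring gives a number 19 percentage points lower from compound 2 to compound 3 (beyond the scatter) and is the first single-change reading at this position. It shows that the group on this oxygen affects growth inhibition at the one concentration tested, which the pair of compound 1 and compound 2 could not show, as those two differ in more than one place. No measurement on hand bears on what lies behind this step.

The compounds shown leave open whether the step belongs to the aromatic ring itself or to its nitro group, a question that an unsubstituted phenyl on the same oxygen would address. Also open, as far as these compounds go, is how a longer chain such as butyl, or a basic group such as a dimethylaminoethyl chain, would read at this position in this assay.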